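Furan-3-yl in place of 4-methoxyphenyl on the shared core

A few compounds are considered here, and "the series" means these few. Any claim that something is new, unique, unknown or untested is made for them only; others in the source may bear on it.

In an ADME assay on Vero cells (Chlorocebus sabaeus) for cytotoxicity, read by MTT assay, with a stated time of 96 h (on this read-out lower numbers stand for higher toxicity in this test and higher numbers for lower toxicity in this test), compound 1 `C/C(=N\NC(N)=S)c1ccc2[nH]c(-c3ccc(C(F)(F)F)cc3)nc2c1` gives 22000 nM. Compound 2 `COc1ccc(-c2nc3cc(/C(C)=N/NC(N)=S)ccc3[nH]2)cc1` gives > 100000 nM, which is a limit of the assay and not a number. Compound 3 `COc1ccc(-c2nc3cc(/C(C)=N/NC(N)=S)ccc3[nH]2)c(OC)c1` gives > 100000 nM, also a limit. Compound 2 therefore has no exact position on the scale, and only compound 1 offers a measured number.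

Compound 4 `C/C(=N\NC(N)=S)c1ccc2[nH]c(-c3ccoc3)nc2c1` differs from compound 2 by the change (furan-3-yl in place of 4-methoxyphenyl on an aromatic carbon). Two measured steps alter the group at this place. The first is an at least 4.5-fold higher number from compound 1 to compound 2 (0.65 log units; beyond the scatter), with methoxy in place of trifluoromethyl on an aromatic carbon. The second is a step that the two limits leave unreadable from compound 2 to compound 3, with methoxy in place of hydrogen on an aromatic carbon. Neither step replaces the whole 4-methoxyphenyl, so they offer only modest guidance. The expectation starts from compound 2 at > 100000 nM, which remains a limit. The estimated step is an at least 1.1-fold lower number from compound 2 to compound 4 (0.04 log units; that floor lies within the scatter), and no change beyond the scatter is expected in this assay. For compound 4 the estimate is 90000 nM, with an expected range from 35000 nM to 200000 nM.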

Compound 4, half-maximal cytotoxic concentration: 100000 nM
Beside the measured number, compound 4's estimate is 1.1-fold (0.05 log units) below it; the range from low to high includes it.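

In this assay compound 4 gives 100000 nM, so the smaller furan-3-yl, with 5 heavy atoms against 8, can replace the whole 4-methoxyphenyl on this aromatic carbon between two ring nitrogen atoms and still yield a number at the high end of the scale, with a number no higher from compound 2 to compound 4 (the limit leaves the size open). Compound 2 gives > 100000 nM, which is a limit of the assay and not a number. The size of the step between these two compounds therefore cannot be read, and the change is seen only at the edge of what the test can show: the limit of > 100000 nM in this assay, at which 2 of the 4 values shown sit.

Among the compounds shown, only compound 1 gives a number well away from that edge, at 22000 nM. As far as these compounds go, whether an aromatic ring is needed here at all stays open, as does what an amine, a carboxylic acid or a short alkyl chain at this place would give.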